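A Benzothiazole in Place of a Chloropyridine on the Triazole

A few compounds are considered here, and "the series" means these few. Any claim that something is new, unique, unknown or untested is made for them only; others in the source may bear on it.

The series shares one core, varied only at the aromatic nitrogen of the triazole. Compound 1 `COc1ccccc1-n1cc(COc2c(/C=C\C(=O)O)ccc(OC)c2CC=C(C)C)nn1` carries a methoxyphenyl there, and in a functional assay on COLO 205 cells (Homo sapiens) for cytotoxicity, read by MTT assay, with a stated time of 24 h (a higher number here means a weaker inhibitor, a lower number a stronger inhibitor), compound 1 gives 12200 nM. Compound 2 `COc1ccc(/C=C\C(=O)O)c(OCc2cn(-c3ccccc3I)nn2)c1CC=C(C)C` carries an iodophenyl, and in this assay compound 2 stands as "not determined" (no result reported). Compound 3 `COc1ccc(/C=C\C(=O)O)c(OCc2cn(-c3cccnc3Cl)nn2)c1CC=C(C)C` carries a 2-chloropyridin-3-yl, and in this assay compound 3 likewise stands as "not determined" (no result reported), so no single number places it; it shares that position with one further entry. The step to compound 4 `COc1ccc(/C=C\C(=O)O)c(OCc2cn(-c3nc4ccccc4s3)nn2)c1CC=C(C)C` is 1,3-benzothiazol-2-yl in place of 2-chloropyridin-3-yl on an aromatic nitrogen. For the measured compounds named here, with no measured step between compound 3 and any neighbour, and only the value of compound 1 as an anchor, the size of the step cannot be read from the data; any change would be expected to stay within the usual scatter of this assay, in no particular direction. Compound 4 is therefore expected to give about 10000 nM in this assay, within a range from 3000 nM to 35000 nM.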

Compound 4, half-maximal inhibitory concentration: 20200 nM
Estimate against measurement, compound 4: 2.0-fold (0.31 log units) below; the range from low to high includes it.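

For the compounds shown here, the result gives the first readable step at this position: in this assay, the change reads a 1.7-fold higher number from compound 1 to compound 4 (0.22 log units; within the scatter), so the two groups cannot be told apart here. A 1,3-benzothiazol-2-yl, with its five-membered aromatic ring and six-membered aromatic ring of carbon only, thus reads the same within the scatter as a single substituted phenyl ring on this aromatic nitrogen. Steps involving compound 2 or compound 3 cannot be read, and no measurement shown here bears on what lies behind the result.

What the compounds shown leave open is whether any group on this aromatic nitrogen moves the value beyond the scatter. An aminophenyl, a carboxyphenyl or a longer alkyl chain there would test this, as all values at this position still rest on two compounds.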